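A Ring Exchange on Compound 3

This account rests on a few compounds, and the source may have more. Where it says the series, first, only, none or still open, it means among the compounds named here.

In an ADME assay on microsomes from liver (Mus musculus) for metabolic stability (on this read-out higher numbers stand for a longer-lived compound and lower numbers for a shorter-lived compound), compound 1 `CC(C)C(c1ccc(-c2ccc3cccc(F)c3c2)[nH]c1=O)N1CCCCS1(=O)=O` gives 0.0733 h, compound 2 `CC(C)C(c1ccc(-c2ccc3cccc(F)c3c2)[nH]c1=O)N1CCN/C1=N\C#N` gives 0.207 h, and compound 3 `CC(C)C(c1nnc[nH]1)c1ccc(-c2ccc3cccc(F)c3c2)[nH]c1=O` gives 0.213 h. Compound 3 thus stands level with compound 2, and both stand above compound 1. Compound 4 `CC(C)C(c1noc(=O)[nH]1)c1ccc(-c2ccc3cccc(F)c3c2)[nH]c1=O` differs from compound 3 by one exchange: a group of 6 heavy atoms (2 carbon, 2 nitrogen, 2 oxygen; one five-membered aromatic ring with 3 hetero atoms) in place of a group of 5 heavy atoms (2 carbon, 3 nitrogen; one five-membered aromatic ring with 3 hetero atoms), on a saturated chain carbon bound to an aromatic carbon and a saturated chain carbon. Within the data shown here, three measured steps touch this same place. Two are modest, a 2.8-fold higher number from compound 1 to compound 2 (0.45 log units; beyond the scatter) and a 2.9-fold higher number from compound 1 to compound 3 (0.46 log units; beyond the scatter), and both leave a six-membered non-aromatic ring. The third, a 1.0-fold higher number from compound 2 to compound 3 (0.01 log units; within the scatter), stays within the scatter. The exchange here keeps a five-membered aromatic ring with 3 hetero atoms, so no step beyond the scatter is expected in this assay. The estimated step is a 1.1-fold lower number from compound 3 to compound 4 (0.03 log units; within the scatter). For compound 4 the estimated half-life is 0.2 h, with an expected range from 0.1 h to 0.4 h.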

Compound 4, half-life: > 3 h
Compound 4 gave a limit, no number; the forecaster's own chance of this, stated with the estimate: 3%; middle value at least 15-fold (1.17 log units) from the limit.
By their numbers in this assay, from the lowest: compound 1; then compounds 2 and 3 (each within the scatter of the next). At a limit, above all of these: compound 4.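

In this assay, compound 4 gives a limit of the assay, not a number: the limit of > 3 h in this assay, at which 1 of the 4 values shown sits. The ring that enters gives an at least 14-fold higher number from compound 3 to compound 4 (1.14 log units; beyond the scatter), so at this saturated chain carbon, exchanging one five-membered aromatic ring for another can change half-life greatly. Among these compounds, the same ring also gives an at least 14-fold higher number from compound 2 to compound 4 (1.16 log units; beyond the scatter) and an at least 40-fold higher number from compound 1 to compound 4 (1.61 log units; beyond the scatter), steps larger than any among the earlier compounds.

From the compounds shown here alone, the true half-life of compound 4 remains unknown, as does which atoms of its ring matter. Going by these compounds, whether a carboxylic acid or a tetrazole at this place would behave the same way also stays open.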